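The compounds below may be only part of what the source reports. "The series", "measured", "known", "first", "only" and "open" are said of these compounds alone.

Compound 2 `CC1N=C(S)N(Nc2cccc(Cl)c2)C1C` has been tested in a functional assay on MT4 cells (Homo sapiens) for cytotoxicity (a lower number here means that less compound is tolerated, a higher number that more compound is tolerated), and gives 259000 nM, the highest of the three numbers recorded so far. Compound 1 `COC(=O)C1N=C(S)N(Nc2cccc(Cl)c2)C1C` gives 48800 nM in this assay, and compound 3 `COc1ccc(-c2c(C)nc(S)n2Nc2cccc(Cl)c2)cc1` gives 38700 nM in this assay; both numbers lie well under that of compound 2. Within the measured set, one change can be followed directly: a 5.3-fold higher number from compound 1 to compound 2 (0.72 log units; beyond the scatter), where methyl replaces methoxycarbonyl on a saturated ring carbon. Compound 4 `CC1N=C(S)N(Nc2cccc(Cl)c2)C1C(=O)O` has not yet been measured. It differs from compound 2 in one place: carboxy in place of methyl on a saturated ring carbon. Because a 5.3-fold higher number from compound 1 to compound 2 (0.72 log units; beyond the scatter) rose when methoxycarbonyl gave way to methyl on a saturated ring carbon, putting a carboxy group onto such a carbon is expected to run the other way, giving a drop beyond the scatter in this assay. Compound 4 is therefore expected to give about 60000 nM in this assay, somewhere between 20000 nM and 180000 nM. That expectation amounts to a 4.3-fold lower number from compound 2 to compound 4 (0.64 log units; beyond the scatter).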

Compound 4, half-maximal cytotoxic concentration: 266000 nM
For compound 4 the middle estimate is 4.4-fold (0.65 log units) below the measured one, and the stated range ends below it.
By their numbers in this assay, from the lowest: compounds 3 and 1 (each within the scatter of the next); then compounds 2 and 4 (each within the scatter of the next).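

In this assay, carboxy in place of methyl on this saturated ring carbon gives a 1.0-fold higher number from compound 2 to compound 4 (0.01 log units; within the scatter) and so leaves compound 2 and compound 4 indistinguishable. This carbon is the one next to the ring atom that bears a group of 8 heavy atoms, whereas the methoxycarbonyl of compound 1 sits on the other saturated ring carbon, so the earlier step of a 5.3-fold higher number from compound 1 to compound 2 (0.72 log units; beyond the scatter) differs from this one in both the group and its place and does not carry over to this position. Nothing at hand accounts for the absence of a shift at this carbon.

Going by these compounds, whether methoxycarbonyl on this same carbon, or carboxy on the other one, would behave like compound 4 stays open. So does the outcome with an amine or a longer chain here.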